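Dropping the Ethyl Branch from an Amide-Linked Dienamide

The compounds below may be only part of what the source reports. "The series", "measured", "known", "first", "only" and "open" are said of these compounds alone.

Two compounds have been examined in a functional assay with platelet-activating factor receptor (Cavia porcellus) as the target; a higher number here means that more compound is needed for the effect, a lower number that less compound is needed. Compound 1, `CC[C@H](CCCc1cccnc1)NC(=O)/C=C/C=C(c1ccc(OC)cc1)c1ccc(OC)cc1`, gives 0.16 mg/kg in this assay. Compound 2, `O=C(/C=C/C=C(c1cccc(F)c1)c1cccc(F)c1)NCCCCc1cccnc1`, gives 0.34 mg/kg in this assay. Compound 1 thus stands at the lowest of the two numbers, and its nearest neighbour, compound 2, sits at a higher number by a margin beyond the usual scatter; as the two structures differ in more than one place, their pair says only what these two values show.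

Compound 3, `COc1ccc(C(=C/C=C/C(=O)NCCCCc2cccnc2)c2ccc(OC)cc2)cc1`, has not yet been measured. It differs from compound 1 in one place: hydrogen in place of ethyl on a saturated chain carbon bound to an amide-type nitrogen and a saturated chain carbon. For the measured compounds named here, no measured pair isolates this change. With compound 2 carrying the same unbranched chain as compound 3, yet a different pair of aryl groups, the evidence is indirect. The step of a 1.6-fold higher number from compound 1 to compound 3 (0.19 log units; within the scatter) is expected to be small, pointing toward a somewhat higher number, and may well stay within the scatter. Compound 3 is therefore estimated at 0.25 mg/kg, within a range from 0.12 mg/kg to 0.55 mg/kg.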

Compound 3, dose for 50% inhibition: 0.25 mg/kg
Estimate against measurement, compound 3: no gap at the digits printed; the measured number falls inside the stated range.
By their numbers in this assay, from the lowest: compounds 1, 3 and 2 (each within the scatter of the next, the first and the last beyond it).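

In this assay, for the compounds shown here, putting hydrogen in place of ethyl on a saturated chain carbon bound to an amide-type nitrogen and a saturated chain carbon gives a 1.6-fold higher number from compound 1 to compound 3 (0.19 log units; within the scatter), and this is the first measured pair that isolates this position. The earlier comparison of two compounds differing in more than one place could not speak to the branch alone; this pair shows that, with the rest of the structure of compound 1 held constant, the loss of the ethyl group and its 2 heavy atoms leaves the reading within the scatter. No measurement shown here explains this outcome, so the pair records the size of the step and gives no reason for it.

On these data alone, what a methyl group, a propyl group or a hydroxymethyl group would do at this carbon remains open, as does the effect of the ethyl group in the opposite stereochemical arrangement. As far as these compounds go, whether a step of this size would also hold with the aryl groups of compound 2 remains open too, since this single pair tests the change only with the aryl groups of compound 1.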